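The compounds below may be only part of what the source reports. "The series", "measured", "known", "first", "only" and "open" are said of these compounds alone.

Working notes on the series. In a functional assay on K562 cells (Homo sapiens), read by MTT assay, with a stated time of 3 days (on this read-out higher numbers stand for weaker inhibition and lower numbers for stronger inhibition), compound 1 `CN(C)c1ncnc2[nH]cc(Sc3cccs3)c12` gives 3830 nM, compound 2 `Nc1ncnc2[nH]cc(Sc3cccs3)c12` gives 17900 nM, and compound 3 `c1csc(Sc2c[nH]c3ncnc(-c4cccs4)c23)c1` gives 5140 nM. Two steps fix the position of the last of these: a 1.3-fold higher number from compound 1 to compound 3 (0.13 log units; within the scatter), and a 3.5-fold lower number from compound 2 to compound 3 (0.54 log units; beyond the scatter). Compound 3 therefore shares the low end of the range with compound 1, while compound 2 has the highest number.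

Compound 4 `Cc1ncnc2[nH]cc(Sc3cccs3)c12` has not yet been measured in this assay. It carries methyl in place of thiophen-2-yl on an aromatic carbon, at the same place on the shared core where the three measured compounds differ: methyl in place of thiophen-2-yl on an aromatic carbon.

Within the data shown here, no methyl analogue is available for comparison, so the guide is the set of steps at this place. Dimethylamino and thiophen-2-yl show no separation, with a 1.3-fold higher number from compound 1 to compound 3 (0.13 log units; within the scatter). Amino is the only group that stands apart, with a 4.7-fold higher number from compound 1 to compound 2 (0.67 log units; beyond the scatter) and a 3.5-fold lower number from compound 2 to compound 3 (0.54 log units; beyond the scatter). These steps are modest at most, so only a small shift is expected, towards a higher number in this assay and probably not clear of the scatter. The expected step is a 1.6-fold higher number from compound 3 to compound 4 (0.19 log units; within the scatter). For compound 4 the estimated value is 8000 nM, with an expected range from 3000 nM to 20000 nM.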

Compound 4, half-maximal inhibitory concentration: 14000 nM
Compound 4: middle estimate off by 1.8-fold (0.24 log units), on the low side; the range from low to high includes it.
By their numbers in this assay, from the lowest: compounds 1 and 3 (each within the scatter of the next); then compounds 4 and 2 (each within the scatter of the next).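

In this assay methyl does not stay with the groups at the low end of the range, as the steps show (a 2.7-fold higher number from compound 3 to compound 4 (0.44 log units; beyond the scatter)) and (a 3.7-fold higher number from compound 1 to compound 4 (0.56 log units; beyond the scatter)), so until now only amino had stood apart at this place, and a second group now does. Methyl and amino show no separation (a 1.3-fold lower number from compound 2 to compound 4 (0.11 log units; within the scatter)), so the four groups fall into two pairs, methyl with amino and dimethylamino with thiophen-2-yl; since dimethylamino carries no ring, the five-membered aromatic ring of thiophen-2-yl is not required for the lower numbers among these compounds. Nothing available here accounts for this division into two pairs.

The compounds shown leave open where an ethyl or a longer alkyl chain, a cyclic amine such as morpholine, or a phenyl ring would fall at this place, and so whether the two pairs are the ends of a graded series or a real division. They also leave open whether the same pairing holds when the thiophen-2-yl group on the sulfur is replaced by another group, such as phenyl.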